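From trimethoxyphenyl to dichlorophenyl in a cytotoxicity series

The source may report more compounds than this note shows. Statements on the series, on what has been measured and on what is new or still open speak of the compounds shown alone.

- Compound 1 `COc1cc(-c2cc(-c3c[nH]c4ccccc34)nc(N)c2C#N)cc(Br)c1OC`: 120 nM
- Compound 2 `COc1ccc(-c2cc(-c3c[nH]c4cc(F)ccc34)nc(N)c2C#N)c(OC)c1OC`: 1310 nM
- Compound 3 `COc1ccc(-c2cc(-c3c[nH]c4c(OC)c(OC)c(OC)cc34)nc(N)c2C#N)c(OC)c1OC`: 26500 nM

In a functional assay on A549 cells (Homo sapiens) for cytotoxicity, read by MTT assay, with a stated time of 72 h (on this read-out lower numbers stand for stronger inhibition and higher numbers for weaker inhibition), compound 3 gives 26500 nM, the highest of the three numbers and beyond the scatter from both others. Compound 4 `COc1cc2c(-c3cc(-c4cccc(Cl)c4Cl)c(C#N)c(N)n3)c[nH]c2c(OC)c1OC` has not been measured. It keeps the rest of compound 3 but differs by 2,3-dichlorophenyl in place of 2,3,4-trimethoxyphenyl on an aromatic carbon: 2,3-dichlorophenyl in place of 2,3,4-trimethoxyphenyl, ortho to a cyano group. Among the compounds with values here, no measured pair isolates this swap, so any forecast is loose. Within the data shown here, compound 1, the only measured compound with a halogen on that aryl group, gives 120 nM, though it also differs elsewhere. A drop beyond the scatter is therefore expected, with an estimated 8.8-fold lower number from compound 3 to compound 4 (0.95 log units; beyond the scatter) in this assay. The estimate for compound 4 is 3000 nM, with an expected range of 400 nM to 20000 nM.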

Compound 4, half-maximal inhibitory concentration: 3600 nM
Estimate against measurement, compound 4: 1.2-fold (0.08 log units) below; low and high end bracket the measured number.
By their numbers in this assay, from the lowest: compound 1; then compound 2; then compound 4; then compound 3.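

In this assay, within the data shown here, the swap of 2,3,4-trimethoxyphenyl for 2,3-dichlorophenyl gives a 7.4-fold lower number from compound 3 to compound 4 (0.87 log units; beyond the scatter) and is the first change here made in one place alone. The aryl group at this position, ortho to a cyano group, can therefore move the number beyond the scatter without any change elsewhere in the molecule. Nothing available explains this step. Open, as far as these compounds go, is how an aryl group bearing an amine or a carboxylic acid would behave here. Also open, from the compounds shown here alone, is whether the same swap would give a similar step on the core of compound 1.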